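Swapping chloro for trifluoromethoxy in compound 1

The source may hold more compounds than are shown below. What is called first, only, known or untested is meant among the compounds shown, and "the series" means these compounds.

Measured in a functional assay on MCF7 cells (Homo sapiens) for inhibition, read by sulforhodamine B assay, with a stated time of 72 h; a higher number here means a weaker inhibitor, a lower number a stronger inhibitor
- Compound 1 `CC(C)Cc1ccc(C(C)c2nnc3n2N=C(c2ccc(Cl)cc2)CS3)cc1` gives 8800 nM
- Compound 2 `CC(c1ccc(-c2ccccc2)c(F)c1)c1nnc2n1N=C(c1ccc(Cl)cc1Cl)CS2` gives 7600 nM
- Compound 3 `CC(c1ccc(-c2ccccc2)c(F)c1)c1nnc2n1N=C(c1ccc(C(F)(F)F)cc1)CS2` gives 4300 nM

Compound 1 at 8800 nM lies within the usual scatter of compound 2, and only compound 3 shows a number clearly lower than it. Compound 4 `CC(C)Cc1ccc(C(C)c2nnc3n2N=C(c2ccc(OC(F)(F)F)cc2)CS3)cc1` is compound 1 with a single change, para to a large group: trifluoromethoxy in place of chloro on an aromatic carbon with the rest of the molecule left as it is.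

Among the measured compounds shown here, no measured compound carries trifluoromethoxy, so the evidence is indirect. The closest measured step is a 1.8-fold lower number from compound 2 to compound 3 (0.25 log units; within the scatter) and it also exchanges one substituted phenyl group for another, this one bearing a fluorinated group. That step is small, and compounds 2 and 3 differ from compound 1 elsewhere in the molecule too, which makes it a modest guide. It points, at most, to a slightly lower number. In this assay no change beyond the scatter is expected, and the estimate is a 1.4-fold lower number from compound 1 to compound 4 (0.13 log units; within the scatter) for this swap. Compound 4 is estimated at 6500 nM with an expected range of 3000 nM to 14000 nM until the measurement arrives.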

Compound 4, half-maximal inhibitory concentration: 1100 nM
Compound 4: middle estimate off by 5.9-fold (0.77 log units), on the high side, and the stated range ends above it.
By their numbers in this assay, from the lowest: compound 4; then compounds 3, 2 and 1 (each within the scatter of the next, the first and the last beyond it).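

At this position, on an aromatic carbon para to a large group, the choice of substituent alone can move the result beyond the scatter: in this assay the swap gives an 8.0-fold lower number from compound 1 to compound 4 (0.90 log units; beyond the scatter) with the rest of the molecule unchanged. Among the compounds shown here, the only earlier step that exchanged one substituted phenyl group for another, a 1.8-fold lower number from compound 2 to compound 3 (0.25 log units; within the scatter), stayed within the scatter and gave no sign that a change on this ring could matter so clearly. Trifluoromethoxy differs from chloro in bringing more heavy atoms, along with oxygen, fluorine and a hydrogen-bond acceptor, but no measurement here separates these differences or explains the lower number.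

A single pair cannot show whether the oxygen, the fluorine atoms or the overall size of the group matters most, and a methoxy group or a dimethylamino group at the same place would help to tell these apart. As far as these compounds go, it also remains open whether trifluoromethoxy would give a similar step on the different remainder of the molecule found in compound 2 and compound 3.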